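This account rests on a few compounds, and the source may have more. Where it says the series, first, only, none or still open, it means among the compounds named here.

In a functional assay on cells (Homo sapiens) for antiproliferative activity, read by MTT assay, with a stated time of 48 h (on this read-out lower numbers stand for stronger inhibition and higher numbers for weaker inhibition), compound 1 `CN(C)CCn1c(N)c(-c2nc3ccccc3[nH]2)c2nc(C#N)c(C#N)nc21` gives 43500 nM, and compound 2 `CCN(CC)CCn1c(N)c(-c2nc3ccccc3[nH]2)c2nc(C#N)c(C#N)nc21` gives 25400 nM. These two sit within the scatter, with a 1.7-fold lower number from compound 1 to compound 2 (0.23 log units; within the scatter). Compound 3 `N#Cc1nc2c(-c3nc4ccccc4[nH]3)c(N)n(CCO)c2nc1C#N` gives > 50000 nM, which is a limit of the assay and not a number. Compound 4 `CN(C)CCCn1c(N)c(-c2nc3ccccc3[nH]2)c2nc(C#N)c(C#N)nc21` differs from compound 3 by (dimethylamino)methyl in place of hydroxy on a saturated chain carbon, two bonds along the chain from an aromatic nitrogen, so 3-(dimethylamino)propyl stands in place of 2-hydroxyethyl. The closest measured changes swap an amine for hydroxy, and they run the opposite way: an at least 1.1-fold higher number from compound 1 to compound 3 (0.06 log units; that floor lies within the scatter) and an at least 1.9-fold higher number from compound 2 to compound 3 (0.29 log units; that floor lies within the scatter). Both floors lie within the scatter, so only a modest fall in this assay is expected, perhaps none beyond the scatter, with an estimated at least 1.5-fold lower number from compound 3 to compound 4 (0.19 log units; that floor lies within the scatter). The estimate for compound 4 is 32000 nM, with an expected range of 15000 nM to 60000 nM.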

Compound 4, half-maximal inhibitory concentration: 1820 nM
Compound 4: the middle estimate sits 18-fold (1.25 log units) above what was measured; measured number below the stated range.
By their numbers in this assay, from the lowest: compound 4; then compounds 2 and 1 (each within the scatter of the next). At a limit, above all of these: compound 3.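

In this assay the 3-(dimethylamino)propyl chain of compound 4 brings a 24-fold lower number from compound 1 to compound 4 (1.38 log units; beyond the scatter) and a 14-fold lower number from compound 2 to compound 4 (1.14 log units; beyond the scatter) and so marks this chain as a sensitive position, whereas dimethylamino and diethylamino on the shorter chain stayed within the scatter of each other. Against the 2-hydroxyethyl chain the change gives an at least 27-fold lower number from compound 3 to compound 4 (1.43 log units; beyond the scatter) as a floor, not an exact size. Compound 3 holds only a limit of the assay: the limit of > 50000 nM in this assay, at which 1 of the 4 values shown sits. Going by these compounds, whether the gain needs the amine stays open, as a 3-hydroxypropyl chain would show. On these data alone, a 3-(diethylamino)propyl chain or a longer 4-(dimethylamino)butyl chain also remains untested here.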